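This account rests on a few compounds, and the source may have more. Where it says the series, first, only, none or still open, it means among the compounds named here.

The measured compounds:
compound 1, `CCOC(=O)c1ccc(-c2nn(Cc3ccc(Cl)cc3)c3ccccc23)cc1`, > 10000 nM (a limit of the assay)
compound 2, `CCOC(=O)c1ccc(-c2nn(Cc3cccc(F)c3)c3ccccc23)cc1`, > 10000 nM (a limit of the assay)
compound 3, `CCOC(=O)c1ccc(-c2nn(Cc3ccccc3OC)c3ccccc23)cc1`, > 10000 nM (a limit of the assay)

In a functional assay on cells (Platelet, Homo sapiens) for inhibition (on this read-out lower numbers stand for stronger inhibition and higher numbers for weaker inhibition), compound 1 reaches only > 10000 nM, which is a limit of the assay and not a number. Compound 2 likewise stops at > 10000 nM, again a limit. Compound 3 also gives > 10000 nM, a limit as well. Compound 1 therefore cannot be placed relative to the other two: all three sit at the limit of > 10000 nM in this assay, at which 3 of the 3 values shown sit, and the steps between them, a step that the two limits leave unreadable from compound 1 to compound 2, a step that the two limits leave unreadable from compound 1 to compound 3 and a step that the two limits leave unreadable from compound 2 to compound 3, have no readable size.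

Compound 4, `CCOC(=O)c1ccc(-c2nn(Cc3cccc(OC)c3)c3ccccc23)cc1`, differs from compound 1 in one place: 3-methoxyphenyl in place of 4-chlorophenyl on a saturated chain carbon bound to an aromatic nitrogen. Every measured step that bears on this change is a swap of one substituted phenyl for another on the same saturated chain carbon bound to an aromatic nitrogen, and none of them yielded a readable size, so nothing in these data suggests that this swap would bring the read-out inside the measurable range. Compound 4 is therefore expected to remain at the limit, with a step that the limit leaves unreadable from compound 1 to compound 4 as the step from compound 1 that this estimate implies. The estimate for compound 4 in this assay is 20000 nM, between 8000 nM and 60000 nM.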

Compound 4, half-maximal inhibitory concentration: > 10000 nM
Compound 4: only a limit was reported (the forecaster's own chance of this, stated with the estimate: 85%); the middle value lies beyond the limit too.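

In this assay compound 4 gives > 10000 nM, a limit of the assay and not a number. Its steps from compound 1, compound 2 and compound 3 cannot be read: the limit of > 10000 nM in this assay, at which 4 of the 4 values shown sit. The compounds shown leave open whether any change to the benzyl group or the shared core would give a measurable value in this assay.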